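Swapping fluoro for methyl on the benzyl ring

The compounds below may be only part of what the source reports. "The series", "measured", "known", "first", "only" and "open" are said of these compounds alone.

Compounds measured so far:
Compound 1, `CC(C(=O)NCc1ccc(C(F)(F)F)nc1N(Cc1ccccc1)S(C)(=O)=O)c1ccc(NS(C)(=O)=O)c(F)c1`: 101 nM
Compound 2, `CC(C(=O)NCc1ccc(C(F)(F)F)nc1N(Cc1ccccc1)S(=O)(=O)C(C)C)c1ccc(NS(C)(=O)=O)c(F)c1`: 18.1 nM
Compound 3, `CC(C(=O)NCc1ccc(C(F)(F)F)nc1N(Cc1ccc(F)cc1)S(=O)(=O)c1ccc(F)cc1)c1ccc(NS(C)(=O)=O)c(F)c1`: 0.71 nM

These three compounds share one core and were compared in an assay on CHO cells for displacement of a labelled ligand from transient receptor potential cation channel subfamily V member 1 (Homo sapiens), read by scintillation counting, with a stated time of 60 min; on this read-out lower numbers stand for stronger inhibition and higher numbers for weaker inhibition. Compound 3 gives the lowest number of the three, and its gap to each of the others is beyond the scatter, so on these numbers it is the most potent. Going by the values given here, the one single-point step among the measured compounds is a 5.6-fold lower number from compound 1 to compound 2 (0.75 log units; beyond the scatter), which concerns the group on the sulfonyl sulfur.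

Compound 4, `Cc1ccc(CN(c2nc(C(F)(F)F)ccc2CNC(=O)C(C)c2ccc(NS(C)(=O)=O)c(F)c2)S(=O)(=O)c2ccc(F)cc2)cc1`, has not yet been measured. It differs from compound 3 by methyl in place of fluoro on an aromatic carbon, para to a large group, so that the 4-fluorobenzyl becomes a 4-methylbenzyl.

Among the compounds with values here, no measured step touches this benzyl ring. The step from compound 1 to compound 2 lies elsewhere on the molecule and gives no guide to swapping one small group for another on an aromatic carbon. With nothing pointing either way, the expected change from compound 3 to compound 4 in this assay is small, most likely within the scatter: a 1.4-fold higher number from compound 3 to compound 4 (0.15 log units; within the scatter). Compound 4 is therefore estimated at 1 nM, with a range from 0.3 nM to 3.5 nM.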

Compound 4, inhibition constant: 3.28 nM
For compound 4 the middle estimate is 3.3-fold (0.52 log units) below the measured one; low and high end bracket the measured number.
By their numbers in this assay, from the lowest: compound 3; then compound 4; then compound 2; then compound 1.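

The benzyl ring is not a silent part of the molecule: in this assay, changing 4-fluorobenzyl to 4-methylbenzyl gives a 4.6-fold higher number from compound 3 to compound 4 (0.66 log units; beyond the scatter). Even this exchange of one heavy atom for one heavy atom, with no hydrogen-bond donor or acceptor entering or leaving, moves the number beyond the usual scatter, so the aromatic carbon para to a large group responds to small changes, and of these two groups fluoro gives the lower number. No measurement shown here explains the gap between fluoro and methyl.

Going by these compounds, with only these two groups compared on this carbon, it remains open how a plain hydrogen, a chloro, a methoxy or a nitrile would compare, and so whether fluoro is unusually favourable or methyl unusually unfavourable. On these data alone, it is also open whether the same fluoro-to-methyl change would have a similar effect on the 4-fluorophenyl group on the sulfonyl sulfur, or with a smaller group such as isopropyl on that sulfur.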